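One Methyl Added Twice, Once Measured, Once Expected

A few compounds are considered here, and "the series" means these few. Any claim that something is new, unique, unknown or untested is made for them only; others in the source may bear on it.

Compound 1, `CC[n+]1ccn(CCN(C)C)c1/C=N/O`, in a physicochemical assay for lipophilicity (a higher number here means a more lipophilic compound, a lower number a more polar compound), gives -2.71.
Compound 2, `CCC[n+]1ccn(CCN(C)C)c1/C=N/O`, in this assay gives -2.73.
Compound 3, `CCN(CCn1cc[n+](C)c1/C=N/O)S(=O)(=O)C(F)(F)F`, in this assay gives -1.03.

Compound 1 and compound 2 differ in one place, (methyl in place of hydrogen on a saturated chain carbon, two bonds along the chain from an aromatic nitrogen), and this change made a number 0.02 log units lower from compound 1 to compound 2 (within the scatter). Compound 3 carries a different core, and how that core differs from the core of compound 1 is not broken down here. In this assay compound 3 stands highest of the three values, beyond the scatter with respect to both compound 1 and compound 2.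

Compound 4, `CCCN(CCn1cc[n+](C)c1/C=N/O)S(=O)(=O)C(F)(F)F`, is not yet measured. It differs from compound 3 by methyl in place of hydrogen on a saturated chain carbon, two bonds along the chain from a sulfonamide nitrogen. This is the same kind of change as that from compound 1 to compound 2, but the place is not the same: there the chain carbon lay two bonds along the chain from an aromatic nitrogen, here it lies two bonds along the chain from a sulfonamide nitrogen. Among the measured compounds shown here, the only measured instance of this kind of change, a number 0.02 log units lower from compound 1 to compound 2 (within the scatter), stayed within the scatter, and that single pair is the whole basis for the expectation. The step from compound 3 to compound 4 is therefore expected to be a number 0.03 log units higher from compound 3 to compound 4 (within the scatter), with the wider range acknowledging that the surroundings of the change are not identical. Compound 4 is accordingly estimated to give -1 in this assay, expected to lie between -1.4 and -0.6.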

Compound 4, distribution coefficient: -0.69
Beside the measured number, compound 4's estimate is 0.31 log units below it; the range from low to high includes it.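

In this assay, the added methyl gave a number 0.34 log units higher from compound 3 to compound 4 (beyond the scatter), whereas the same kind of change on the core of compound 1 gave a number 0.02 log units lower from compound 1 to compound 2 (within the scatter), so a step that stayed within the scatter on one core went beyond it on the other. This shows that in this series the step seen on one core did not carry over unchanged to the other, although the group that enters is the same methyl and the difference reads ethyl to propyl in both pairs. It does not show whether the core or the place of the change, two bonds along the chain from an aromatic nitrogen in one pair and from a sulfonamide nitrogen in the other, sets the two steps apart, and with a single pair on each core no rule can be drawn, nor does any supporting measurement bear on the result.

The compounds shown leave open whether a longer chain, butyl in place of propyl, would extend either step. They also leave open how the same ethyl to propyl change would read if an amide stood in place of the sulfonamide.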